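Trifluoromethyl for methoxy on the aryloxy propanolamine

The source may report more compounds than this note shows. Statements on the series, on what has been measured and on what is new or still open speak of the compounds shown alone.

In an assay on isolated protein for inhibition of sodium channel protein type 9 subunit alpha (Mus musculus), read by patch clamp (on this read-out higher numbers stand for weaker inhibition and lower numbers for stronger inhibition), compound 2 `COc1ccc(OCC(O)CN2CCC(N3Cc4ccccc4C3=O)CC2)cc1` gives 1300 nM. Its only companion in this assay is compound 1 `O=C(Nc1ccccc1)C1CCN(CC(O)COc2ccc(C(F)(F)F)cc2)CC1`, which gives 800 nM; the two numbers lie within the usual scatter of each other, so neither can be called the stronger inhibitor on what is shown. Compound 3 `O=C1c2ccccc2CN1C1CCN(CC(O)COc2ccc(C(F)(F)F)cc2)CC1` is not yet measured. It differs from compound 2 in one place: trifluoromethyl in place of methoxy on an aromatic carbon. Within the data shown here, no measured pair in this set shows that change alone, so its effect is unknown; the only hint is that compound 1, which also carries the trifluoromethyl group, gives 800 nM in this assay. The step from compound 2 to compound 3 is therefore expected to be small, a 1.6-fold lower number from compound 2 to compound 3 (0.21 log units; within the scatter), with no clear direction beyond the scatter. In this assay compound 3 is estimated at 800 nM, within a range from 300 nM to 2500 nM.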

Compound 3, half-maximal inhibitory concentration: 100 nM
The estimate for compound 3 lay 8.0-fold (0.90 log units) above the measured number; the measured number lies below the stated range.
By their numbers in this assay, from the lowest: compound 3; then compounds 1 and 2 (each within the scatter of the next).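

In this assay this place on the aromatic ring, para to a large group, now has its first single-change reading: trifluoromethyl in place of methoxy gives a 13-fold lower number from compound 2 to compound 3 (1.11 log units; beyond the scatter) and so matters far more here than the earlier pair could suggest. The group on the saturated ring carbon also matters with trifluoromethyl held fixed, as the change there gives an 8.0-fold lower number from compound 1 to compound 3 (0.90 log units; beyond the scatter) and shows that trifluoromethyl alone does not set the number. Nothing available bears on why either step occurs.

The compounds shown leave open whether the drop is particular to trifluoromethyl or would also come with a chlorine atom or a nitrile at the same place. They also leave open whether the same change would give a step of similar size on the core of compound 1.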